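The compounds below may be only part of what the source reports. "The series", "measured", "known", "first", "only" and "open" are said of these compounds alone.

Within the data shown here, compound 2 `O=c1n(Cc2cn3ccc(Cl)cc3n2)c2cnccc2n1C1CC1` gives in an ADME assay on HEp-2 cells (Homo sapiens) for cytotoxicity, read by CCK-8 assay, with a stated time of 6 days (on this read-out higher numbers stand for lower toxicity in this test and lower numbers for higher toxicity in this test), a value of 22300 nM, the only plain number among the three measured compounds. Compound 1 `O=c1n(Cc2nc3ccc(F)cn3c2CCCCO)c2cnccc2n1C1CC1` reaches only a limit, > 100000 nM. Compound 3 `O=C(CCc1c(Cn2c(=O)n(C3CC3)c3ccncc32)nc2cc(Cl)ccn12)NCCO` likewise sits at a limit, > 100000 nM. Among the measured compounds shown here, the single measured step that changes one place, an at least 4.4-fold higher number from compound 2 to compound 3 (0.65 log units; beyond the scatter), went toward lower toxicity, and the limit of > 100000 nM in this assay, at which 2 of the 3 values shown sit, shows where that step ends. Compound 4 `O=c1n(Cc2nc3cc(Cl)ccn3c2NC2CCCCC2)c2cnccc2n1C1CC1` differs from compound 2 by cyclohexylamino in place of hydrogen on an aromatic carbon. For the measured compounds named here, no measured step covers this particular change, so the author takes the one measured step only as a hint of direction. For compound 4 the expected step is a 1.8-fold higher number from compound 2 to compound 4 (0.25 log units; within the scatter), modest and toward a higher number. Compound 4 is therefore estimated at 40000 nM, between 10000 nM and 100000 nM.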

Compound 4, half-maximal cytotoxic concentration: > 100000 nM
Compound 4: only a limit was reported; the forecaster's own chance of this, stated with the estimate: 40%; middle value at least 2.5-fold (0.39 log units) away from the limit.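

In this assay, a second and quite different group on this aromatic carbon moves the number the same way, with cyclohexylamino giving an at least 4.4-fold higher number from compound 2 to compound 4 (0.65 log units; beyond the scatter). Compound 4 reaches only a limit, and the step between compound 3 and compound 4 cannot be read. The true size of the change from hydrogen stays unknown because the value ends at a limit: the limit of > 100000 nM in this assay, at which 3 of the 4 values shown sit.

Going by these compounds, whether methylamino or a carboxylic acid on this carbon would give a plain number remains open. So does any ranking of cyclohexylamino against 2-((2-hydroxyethyl)carbamoyl)ethyl.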